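The source may hold more compounds than are shown below. What is called first, only, known or untested is meant among the compounds shown, and "the series" means these compounds.

Compound 1 `CN(C)c1ccc(C2CC(c3ccc(-n4cncn4)cc3)=NN2)cc1` gives 7% in a functional assay on MDA-MB-231 cells (Homo sapiens) for inhibition, read by sulforhodamine B assay, tested at 10 uM; on this read-out lower numbers stand for less inhibition and higher numbers for more inhibition at the one concentration tested (going by the name of the read-out). Compound 2 `CN1CCN(c2ccc(C3=NN(C(=O)c4ccc(F)cc4)C(c4ccc(N(C)C)cc4)C3)cc2)CC1` gives 3.5%. Compound 3 `COC(=O)CC(=O)N1N=C(c2ccc(-n3cncn3)cc2)CC1c1ccc(N(C)C)cc1` gives 6.8%.

Compound 3 stands second highest of these three numbers in this assay, with compound 1 nearest and compound 2 furthest, both gaps within the usual scatter. Compound 4 `CN(C)c1ccc(C2CC(c3ccc(-n4cncn4)cc3)=NN2C(=O)c2ccc(F)cc2)cc1` differs from compound 3 by 4-fluorophenyl in place of (methoxycarbonyl)methyl on a carbonyl carbon. Among the compounds with values here, the only measured step touching the same place is a number 0.2 percentage points lower from compound 1 to compound 3 (within the scatter), which moved nothing beyond the scatter. Compound 2, which also carries a (4-fluorophenyl)carbonyl group on its ring nitrogen, sits close to the other two as well. A step of no real size is therefore expected, a number 1.8 percentage points lower from compound 3 to compound 4 (within the scatter). Compound 4 is estimated at 5%, between -4% and 14%.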

Compound 4, a percentage reported as inhibition, at one concentration (the size of the read-out at that concentration, not a potency): 12.5%
The estimate for compound 4 lay 7.5 percentage points below the measured number; measured number inside the range.
By their numbers in this assay, from the lowest: compounds 2, 3, 1 and 4 (each within the scatter of the next).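

In this assay there is a number 5.5 percentage points higher from compound 1 to compound 4 (within the scatter) with (4-fluorophenyl)carbonyl in place of hydrogen on an amine nitrogen in a ring, and a number 5.7 percentage points higher from compound 3 to compound 4 (within the scatter) with 4-fluorophenyl in place of (methoxycarbonyl)methyl on a carbonyl carbon. At another place there is a number 9 percentage points higher from compound 2 to compound 4 (within the scatter) with 1H-1,2,4-triazol-1-yl in place of 4-methylpiperazin-1-yl on an aromatic carbon, so neither place has yet moved the number beyond the scatter. No measurement here explains these steps.

Going by these compounds, whether a carboxylic acid or an amine on that carbonyl carbon would move the number beyond the scatter stays open.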